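Cytotoxicity of a butoxy analogue predicted from inert congeners

The source may hold more compounds than are shown below. What is called first, only, known or untested is meant among the compounds shown, and "the series" means these compounds.

Compound 3 `Nc1nc(OCc2ccccc2)c2ncn(/C=C3/CC3(CO)CO)c2n1` is one of three congeners examined in an ADME assay on Akata cells (Homo sapiens) for cytotoxicity, with a stated time of 7 days; a lower number here means that less compound is tolerated, a higher number that more compound is tolerated. In this assay compound 3 gives > 20000 nM, which is a limit of the assay rather than a number. Compound 1 `CCCCSc1nc(N)nc2c1ncn2/C=C1/CC1(CO)CO` gives > 20000 nM in this assay, again a limit. Compound 2 `Nc1nc(OCC(F)(F)F)c2ncn(/C=C3/CC3(CO)CO)c2n1` gives > 20000 nM in this assay, also a limit. Every value shown thus rests at the limit of > 20000 nM in this assay, at which 3 of the 3 values shown sit, so compound 3 cannot be ranked against its neighbours: the steps a step that the two limits leave unreadable from compound 1 to compound 3 and a step that the two limits leave unreadable from compound 2 to compound 3 are both unreadable, as is a step that the two limits leave unreadable from compound 1 to compound 2.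

Compound 4 `CCCCOc1nc(N)nc2c1ncn2/C=C1/CC1(CO)CO` differs from compound 3 by propyl in place of phenyl on a saturated chain carbon bound to an oxygen on an aromatic ring. Within the data shown here, the only step that touches the same place on the molecule is the one from compound 2 to compound 3, and its size could not be read, so no measured step gives a usable size or direction for the change at hand. Because every value shown sits at the limit of > 20000 nM in this assay, at which 3 of the 3 values shown sit, the expectation for compound 4 is simply that it, too, will be tolerated up to the limit. The estimate for compound 4 in this assay is 20000 nM, with an expected range from 10000 nM to 40000 nM. The expected step is a number no higher from compound 3 to compound 4 (the limit leaves the size open), that is, none beyond the scatter.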

Compound 4, half-maximal cytotoxic concentration: > 20000 nM
Compound 4: only a limit was reported; the forecaster's own chance of this, stated with the estimate: 85%; the middle value sits exactly at the limit.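

No step among compound 1, compound 2, compound 3 and compound 4 can be read in this assay, since all of them rest at one limit: the limit of > 20000 nM in this assay, at which 4 of the 4 values shown sit.

The compounds shown leave open whether butylsulfanyl, 2,2,2-trifluoroethoxy, benzyloxy and butoxy differ at all in cytotoxicity, and at what concentration any of these compounds would become cytotoxic.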